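Amino for Chloro on the Shared Core

The source may report more compounds than this note shows. Statements on the series, on what has been measured and on what is new or still open speak of the compounds shown alone.

Compound 1 `ClCc1ccccc1Cn1cnc2c(Cl)nc(Cl)nc21` carries two chloro groups on its core, and a benzyl arm bearing a chloromethyl group. Its close relative, compound 2 `ClCc1ccc(Cn2cnc3c(Cl)nc(Cl)nc32)cc1`, has been tested in a functional assay on SK-MEL-28 cells (Homo sapiens) for cytotoxicity, read by sulforhodamine B assay, with a stated time of 48 h (on this read-out lower numbers stand for higher toxicity in this test and higher numbers for lower toxicity in this test), where compound 2 gives 46800 nM, a weak cytotoxic effect. For compound 1 in this assay the record holds only "not determined" (no result reported), so compound 1 stands at no number of its own, and the one point of reference is the weak result of compound 2.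

Compound 3 `Nc1nc(Cl)c2ncn(Cc3ccccc3CCl)c2n1` is reached from compound 1 by the change (amino in place of chloro on an aromatic carbon), the new amino group sitting between two ring nitrogen atoms, meta to a chloro group. Within the data shown here, no step between measured compounds is available to anchor this change, so the size of the step in this assay is uncertain; a shift of moderate size in either direction, or none beyond the scatter, is all that can be expected from the sparse record. Drawing on compound 2 in this assay at 46800 nM, the lethal concentration for compound 3 is expected near 40000 nM, within a range of 10000 nM to 160000 nM.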

Compound 3, concentration lethal to 50% of the cells: 74100 nM
The estimate for compound 3 lay 1.9-fold (0.27 log units) below the measured number; low and high end bracket the measured number.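

No step can be read from compound 1 to compound 3 in this assay, where compound 3 gives 74100 nM and compound 1 has no number to set against it. The compounds shown leave open what amino in place of chloro on the shared core does to this read-out. No measured evidence bears on this result.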